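Second chloro on the core of compound 1

The source may report more compounds than this note shows. Statements on the series, on what has been measured and on what is new or still open speak of the compounds shown alone.

Measured so far:
compound 1 `ClCc1ccccc1Cn1cnc2ncnc(Cl)c21` — 1990 nM
compound 2 `ClCc1ccc(Cn2cnc3c(Cl)nc(Cl)nc32)cc1` — 1380 nM
compound 3 `Nc1nc(Cl)c2ncn(Cc3cccc(CCl)c3)c2n1` — 6020 nM

Of the compounds shown here, three have been tested in a functional assay on T47D cells (Homo sapiens) for cytotoxicity, read by sulforhodamine B assay, with a stated time of 48 h; on this read-out higher numbers stand for weaker inhibition of growth and lower numbers for stronger inhibition of growth. Compound 1 gives 1990 nM, the second highest of the three numbers. Its nearest neighbour is compound 2, which gives 1380 nM; the two values lie within the scatter of each other. Compound 3 gives 6020 nM, a number beyond the scatter above compound 1. No two of these compounds differ in only one place, so no single step can be read from them.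

Compound 4 `ClCc1ccccc1Cn1cnc2nc(Cl)nc(Cl)c21` has not been measured. It differs from compound 1 by chloro in place of hydrogen on an aromatic carbon. The nearest point of comparison is compound 2, whose core also carries two chloro groups, yet compound 2 differs from compound 1 in a second place as well, so its value can only hint at the outcome. On this basis the step is expected to stay within the scatter, and compound 4 is estimated at 1500 nM (range 600 nM to 4000 nM), a step of a 1.3-fold lower number from compound 1 to compound 4 (0.12 log units; within the scatter) in this assay.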

Compound 4, concentration for 50% growth inhibition: 580 nM
For compound 4 the middle estimate is 2.6-fold (0.41 log units) above the measured one, outside the stated range (below it).
By their numbers in this assay, from the lowest: compound 4; then compounds 2 and 1 (each within the scatter of the next); then compound 3.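

In this assay, this pair gives the series its first single step: chloro in place of hydrogen on an aromatic carbon, between two ring nitrogen atoms, gives a 3.4-fold lower number from compound 1 to compound 4 (0.54 log units; beyond the scatter), a modest change. Among the compounds shown here, this shows that the position is not silent on this read-out, which the earlier compounds could not show, as none of them differs from another in only one place. No supporting data bear on why the number falls.

This single pair cannot tell whether a bromo or a methoxy group at the same position would give a number like that of compound 4. Going by these compounds, whether the step would repeat with the chloromethyl group placed elsewhere in the molecule also stays open.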